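The compounds below may be only part of what the source reports. "The series", "measured", "known", "first", "only" and "open" are said of these compounds alone.

Compound 1, `CCC(CC)(c1ccc(OCC(O)CO)c(C)c1)c1ccc(OCC(O)C(C)(C)C)c(OCC(O)C(C)(C)C)c1`: 78%
Compound 2, `CCC(CC)(c1ccc(OCCCC(=O)O)c(C)c1)c1ccc(OCC(O)C(C)(C)C)c(OCC(O)C(C)(C)C)c1`: 14%

Among the compounds with values here, both compounds were tested in an assay on cells for binding affinity to vitamin D3 receptor (Homo sapiens), read by fluorescence, tested at 1 uM (a higher number here means more inhibition at the concentration tested (going by the name of the read-out), a lower number less inhibition), a measurement in which compound 2 stands lowest of the two numbers; its nearest neighbour is compound 1, and the only measured step, a number 64 percentage points lower from compound 1 to compound 2 (beyond the scatter), separates them. Compound 3, `CCC(CC)(c1ccc(OS(=O)(=O)c2ccc([N+](=O)[O-])cc2)c(C)c1)c1ccc(OCC(O)C(C)(C)C)c(OCC(O)C(C)(C)C)c1`, differs from compound 2 in one place: (4-nitrophenyl)sulfonyl in place of 3-carboxypropyl on an oxygen on an aromatic ring.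

Within the data shown here, no measured step involves the group that enters here, so there is no direct guide. Among the measured compounds shown here, the one step known, a number 64 percentage points lower from compound 1 to compound 2 (beyond the scatter), shows only that exchanging the group on this oxygen can move the number a great deal, and that compound 1, which carries a different group at the same place, reached 78%. The direction for compound 3 is therefore uncertain, and a moderate rise, a number 16 percentage points higher from compound 2 to compound 3 (beyond the scatter), is expected with wide bounds. For compound 3 the estimate is 30%, in a range from 5% to 65%.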

Compound 3, a percentage reported as inhibition, at one concentration (the size of the read-out at that concentration, not a potency): 29%
For compound 3 the middle estimate is 1 percentage points above the measured one; the measured number falls inside the stated range.
By their numbers in this assay, from the lowest: compound 2; then compound 3; then compound 1.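

Putting (4-nitrophenyl)sulfonyl in place of 3-carboxypropyl on this oxygen gives a number 15 percentage points higher from compound 2 to compound 3 (beyond the scatter) in this assay, so a larger group with an aromatic ring and no hydrogen-bond donor still gives a measurable read-out here. Set against 2,3-dihydroxypropyl, the same group gives a number 49 percentage points lower from compound 1 to compound 3 (beyond the scatter), which leaves compound 1 with the highest number of the three, beyond the scatter from both others. Nothing available explains why these three groups rank in this order.

As far as these compounds go, it remains open whether an amine, an amide or a single hydroxyl-bearing chain on this oxygen would come close to compound 1. Also open, from the compounds shown here alone, is what a plain phenylsulfonyl group, without the nitro group, would give, which would separate the contribution of the sulfonyl link from that of the nitro group.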